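A few compounds are considered here, and "the series" means these few. Any claim that something is new, unique, unknown or untested is made for them only; others in the source may bear on it.

Of the compounds shown here, three have been tested so far, and one more awaits its result. Compound 1 `CCOc1ccc2nc(Cl)c(/C=N/NC(=O)c3cc4cc([N+](=O)[O-])ccc4oc3=O)cc2c1` and compound 2 `CCOc1ccc2nc(Cl)c(/C=N/NC(=O)c3cc4ccccc4oc3=O)cc2c1` share one core, while compound 3 `CCOc1ccc(NC(=O)c2cc3cc([N+](=O)[O-])ccc3oc2=O)cc1` and compound 4 `CCOc1ccc(NC(=O)c2cc3ccccc3oc2=O)cc1` share another; the difference between the two cores is not broken down here.

In a functional assay on PANC-1 cells (Homo sapiens) for antiproliferative activity, read by fluorescence and resazurin assay, with a stated time of 48 h (on this read-out lower numbers stand for stronger inhibition and higher numbers for weaker inhibition), compound 1 gives 10500 nM and compound 2 gives 29900 nM. The change between them is hydrogen in place of nitro on an aromatic carbon, and it produced a 2.8-fold higher number from compound 1 to compound 2 (0.45 log units; beyond the scatter).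

Compound 3 gives 12100 nM in this assay, a value that sits within the scatter of compound 1 and beyond it relative to compound 2.

Compound 4 carries the same change on the second core: hydrogen in place of nitro on an aromatic carbon. Because the earlier step of a 2.8-fold higher number from compound 1 to compound 2 (0.45 log units; beyond the scatter) weakened the activity modestly, a step of similar size is expected here. The estimate for compound 4 is therefore 30000 nM in this assay, with a plausible range from 12000 nM to 80000 nM. Among the compounds with values here, this corresponds to an expected step of a 2.5-fold higher number from compound 3 to compound 4 (0.39 log units; beyond the scatter), resting only on the single earlier example of the same change.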

Compound 4, half-maximal inhibitory concentration: 13400 nM
Compound 4: middle estimate off by 2.2-fold (0.35 log units), on the high side, within the range that was stated.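

In this assay, putting hydrogen in place of nitro on the second core gives a 1.1-fold higher number from compound 3 to compound 4 (0.04 log units; within the scatter), so on this core the change has no effect that can be told apart from the scatter. Set beside the same change on the first core, the two steps look different in size, yet the gap between them is no larger than two such steps can show by chance: the same change on two cores in this assay, a 2.8-fold higher number (0.45 log units; beyond the scatter) from compound 1 to compound 2 and a 1.1-fold higher number (0.04 log units; within the scatter) from compound 3 to compound 4, 2.6-fold (0.41 log units) apart, within the scatter of two such steps This means the data neither show that the change carries over from one core to the other with the same size nor show that the core alters it, since one step per core is too little to settle the question.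

The compounds shown carry only nitro or hydrogen at this place, so what an amine, a methoxy group or a carboxylic acid would do there remains open. Also open, on these data alone, is whether any such group would behave alike on both cores.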